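Jurkat growth series: phenyl for methyl, compound 3

The source may hold more compounds than are shown below. What is called first, only, known or untested is meant among the compounds shown, and "the series" means these compounds.

Measured compounds:
compound 1, `CN/C=N/c1cc(-c2ccccc2)nn1-c1ccccc1`, in a functional assay on Jurkat cells (Homo sapiens) for inhibition, read by MTT assay, with a stated time of 72 h; a lower number here means a stronger inhibitor of growth, a higher number a weaker inhibitor of growth: > 50000 nM
compound 2, `C/C(=N\c1cc(-c2ccccc2)nn1-c1ccccc1)N(C)C`, in this assay: > 50000 nM

Both values are limits of the assay, not numbers. Compound 2 stands at the limit in this assay, so its place relative to compound 1 cannot be read from the numbers. For the measured compounds named here, the single measured step, a step that the two limits leave unreadable from compound 1 to compound 2, puts a group of 6 heavy atoms (4 carbon, 2 nitrogen; no ring) in place of a group of 4 heavy atoms (2 carbon, 2 nitrogen; no ring) on an aromatic carbon, and its size is hidden by the limits; both compounds sit at the limit of > 50000 nM in this assay, at which 2 of the 2 values shown sit.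

Compound 3, `CN(C)/C(=N/c1cc(-c2ccccc2)nn1-c1ccccc1)c1ccccc1`, differs from compound 2 by phenyl in place of methyl on a carbon with a double bond to nitrogen, whose other neighbours are an amine nitrogen and a double-bonded nitrogen. Going by the values given here, no measured step gives a readable size that bears on this change; the only step available is unreadable. For compound 3 the expected step is an at least 1.1-fold lower number from compound 2 to compound 3 (0.04 log units; that floor lies within the scatter), none beyond the scatter, and a further limit is the most likely outcome. The estimate for compound 3 in this assay is 45000 nM, with a range from 10000 nM to 250000 nM.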

Compound 3, concentration for 50% growth inhibition: 36100 nM
Compound 3: middle estimate off by 1.2-fold (0.10 log units), on the high side; the range from low to high includes it.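

In this assay compound 3, with phenyl on the carbon with a double bond to nitrogen, gives 36100 nM, a measured number and not a limit of the assay. The other compounds shown remain at a limit, and the step between them cannot be read: the limit of > 50000 nM in this assay, at which 2 of the 3 values shown sit.

Phenyl in place of methyl at this position thus gives the series its first readable step, an at least 1.3-fold lower number from compound 2 to compound 3 (0.14 log units; that floor lies within the scatter), which is a floor only and does not by itself establish a change beyond the scatter.

On these data alone, the true size of this step remains open, as the starting point is a limit and the step is bounded on one side only. Also open, as far as these compounds go, is whether another group on this carbon, such as a longer chain like propyl, a saturated ring like cyclohexyl or a pyridine ring, or a phenyl carrying a methoxy group or a chlorine, would move the number in this assay further from the limit, and whether a morpholine in place of the dimethylamino group would keep a readable value.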